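Swapping a methoxy-bearing side chain for cyclohexyl

The source may hold more compounds than are shown below. What is called first, only, known or untested is meant among the compounds shown, and "the series" means these compounds.

Compound 1 `COC(C)(C)[C@@H](O)C(=O)N1[C@H](C(=O)NCc2cc(Cl)ccc2-n2cnnn2)C[C@@H]2C[C@@H]21` carries a 1-methoxy-1-methylethyl group on the carbon that also bears the hydroxyl, and in an ADME assay on Caco-2 cells (Homo sapiens) for permeability, read by LC-MS, in the apical to basolateral direction, with a stated time of 60 min, at pH 6.5 (on this read-out lower numbers stand for lower permeability and higher numbers for higher permeability), compound 1 gives 16 10^-6 cm/s, the highest of the three numbers at hand. Compound 3 `CC(C)(C)[C@@H](O)C(=O)N1NCC[C@H]1C(=O)NCc1cc(Cl)ccc1-n1cnnn1` gives 7.2 10^-6 cm/s in this assay, and compound 2 `O=C(NCc1cc(Cl)ccc1-n1cnnn1)[C@@H]1CCNN1C(=O)[C@H](O)c1ccccc1` gives 5.3 10^-6 cm/s. The change to compound 4 `O=C(NCc1cc(Cl)ccc1-n1cnnn1)[C@@H]1C[C@@H]2C[C@@H]2N1C(=O)[C@H](O)C1CCCCC1` is cyclohexyl in place of 1-methoxy-1-methylethyl on a saturated chain carbon bound to a carbonyl carbon and an oxygen on a saturated carbon. Within the data shown here, only one measured step touches the same place: a 1.4-fold higher number from compound 2 to compound 3 (0.13 log units; within the scatter), a change of the substituent on that carbon that stayed within the scatter. Nothing measured removes the methoxy oxygen. Compound 4 is therefore expected to stay close to compound 1, with a 1.3-fold higher number from compound 1 to compound 4 (0.10 log units; within the scatter), giving an estimate of 20 10^-6 cm/s within a range of 10 10^-6 cm/s to 40 10^-6 cm/s.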

Compound 4, apparent permeability: 16 10^-6 cm/s
Compound 4: middle estimate off by 1.3-fold (0.10 log units), on the high side; the measured number falls inside the stated range.
By their numbers in this assay, from the lowest: compounds 2 and 3 (each within the scatter of the next); then compounds 1 and 4 (each within the scatter of the next).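

In this assay, cyclohexyl in place of 1-methoxy-1-methylethyl on a saturated chain carbon bound to a carbonyl carbon and an oxygen on a saturated carbon gives no change at the digits printed from compound 1 to compound 4 (within the scatter). Among these compounds, the methoxy oxygen can thus be replaced by an all-carbon ring on the core of compound 1 without a change beyond the scatter, whereas the only earlier step at this place was on the core of compound 2. Nothing given here explains this result. Going by these compounds, whether an amine or a carboxylic acid at this place would also leave the number within the scatter stays open.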